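Swapping One Chloro for Fluoro on Compound 2

The source may hold more compounds than are shown below. What is called first, only, known or untested is meant among the compounds shown, and "the series" means these compounds.

Compound 1 `Cc1oc2c([C@H]3CCN(C)C[C@H]3O)c(O)cc(O)c2c(=O)c1C(O)c1cccc(Cl)c1`: 4%
Compound 2 `Cc1oc2c([C@H]3CCN(C)C[C@H]3O)c(O)cc(O)c2c(=O)c1C(O)c1c(Cl)cccc1Cl`: 24%

Among the compounds with values here, in a functional assay on Caco-2 cells (Homo sapiens) for inhibition, read by MTT assay, with a stated time of 48 h, tested at 10 uM (a higher number here means more inhibition of growth at the concentration tested, a lower number less inhibition of growth), compound 2 stands highest of the two measured so far, at 24%. Compound 3 `Cc1oc2c([C@H]3CCN(C)C[C@H]3O)c(O)cc(O)c2c(=O)c1C(O)c1c(F)cccc1Cl` has fluoro in place of chloro on an aromatic carbon, ortho to a large group (fluoro in place of chloro on an aromatic carbon). Within the data shown here, only one measured step bears on this change: a number 20 percentage points higher from compound 1 to compound 2 (beyond the scatter). That modest step, 2,6-dichlorophenyl in place of 3-chlorophenyl, does not test a single chloro alone. A smaller downward step is expected, possibly within the scatter. The expected change is a number 7 percentage points lower from compound 2 to compound 3 (within the scatter). The estimate for compound 3 is 17%, with an expected range of 3% to 35%.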

Compound 3, percent growth inhibition at one concentration: 18%
Compound 3: the middle estimate sits 1 percentage points below what was measured; the range from low to high includes it.
By their numbers in this assay, from the lowest: compound 1; then compounds 3 and 2 (each within the scatter of the next).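

Fluoro can take the place of one chloro on the 2,6-dichlorophenyl group with little visible effect: the change gives a number 6 percentage points lower from compound 2 to compound 3 (within the scatter) and so does not separate the two compounds in this growth read-out. The 2-chloro-6-fluorophenyl group also keeps a gain over the 3-chlorophenyl group, with a number 14 percentage points higher from compound 1 to compound 3 (beyond the scatter) as the step. No measurement shown here explains either step.

Still open, from the compounds shown here alone, is whether a 2,6-difluorophenyl group, with fluoro on both sides, would hold the number. A methoxy group or an amine at this same place also remains an open question.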